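This account rests on a few compounds, and the source may have more. Where it says the series, first, only, none or still open, it means among the compounds named here.

Compound 1 `COc1ccc(/C=C2/N=C(c3ccccc3)N(C(=O)c3ccc(Cl)cc3)NC2=O)cc1`: "not active" (no number reported)
Compound 2 `Cc1ccc(C(=O)N2NC(=O)/C(=C\c3ccc(O)cc3)N=C2c2ccccc2)cc1`: 100 mg/kg
Compound 3 `Cc1ccc(/C=C2/N=C(c3ccccc3)N(C(=O)c3ccc(C)cc3)NC2=O)cc1`: 100 mg/kg

In a functional assay on the whole organism (strain albino) with Mus musculus as the target, with a stated time of 4 h (a lower number here means that less compound is needed, a higher number that more compound is needed for the effect), compound 3 gives 100 mg/kg and stands level with compound 2 at the digits reported, the step of no change at the digits printed from compound 2 to compound 3 (within the scatter) lying within the scatter. Compound 1 is reported in this assay only as "not active" (no number reported), with no number behind it.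

Compound 4 `COc1ccc(/C=C2/N=C(c3ccccc3)N(C(=O)c3ccc(C)cc3)NC2=O)cc1` differs from compound 3 by methoxy in place of methyl on an aromatic carbon. Within the data shown here, no measured step covers this exact exchange. Among the measured compounds shown here, the one measured step, no change at the digits printed from compound 2 to compound 3 (within the scatter), swapped one small group for another on the same ring and left the read-out unchanged, so a step within the scatter is the expectation here as well: no change at the digits printed from compound 3 to compound 4 (within the scatter). Compound 1 also carries the methoxy group and was not active, but it differs from compound 4 at a second place too, so its result alone cannot settle the outcome; it does raise the chance that no number is returned. Compound 4 is therefore expected to give 100 mg/kg, within a range from 50 mg/kg to 200 mg/kg.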

Compound 4, dose for half-maximal effect: 100 mg/kg
Compound 4: the middle estimate sits on the measured number at the digits printed; low and high end bracket the measured number.
By their numbers in this assay, from the lowest: compounds 2, 3 and 4 (each within the scatter of the next).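

With the 4-methylphenyl to 4-methoxyphenyl exchange, this assay shows no change at the digits printed from compound 3 to compound 4 (within the scatter) at this position para to a large group, so a second exchange there also leaves the read-out in place. Methylation of the oxygen, which had not been covered before, gives no change at the digits printed from compound 2 to compound 4 (within the scatter), so hydroxy, methyl and methoxy all stand level here. Compound 4 also shares its methoxy group with compound 1, which is reported as "not active" (no number reported) and differs from compound 4 only on the other aromatic ring, so the methoxy group alone does not go with the missing number.

As far as these compounds go, whether an amine, a carboxylic acid or a longer chain such as butoxy at this position would hold the same level remains open. Nothing available explains why these groups stand level or why compound 1 has no number.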